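The source may hold more compounds than are shown below. What is called first, only, known or untested is meant among the compounds shown, and "the series" means these compounds.

In a functional assay on blood (Homo sapiens), with a stated time of 60 min, in the presence of a further agent that is not named here (a lower number here means that less compound is needed, a higher number that more compound is needed for the effect), the measured compounds are these:

Compound 1 `O=C(Oc1ccccc1)C1(S(=O)(=O)c2ccc(Oc3ccc(OC(F)(F)F)cc3)cc2)CCC2(CCNCC2)C1` gives 900 nM
Compound 2 `Nc1ccccc1NC(=O)C1(S(=O)(=O)c2ccc(Oc3ccc(OC(F)(F)F)cc3)cc2)CCC2(CCNCC2)C1` gives 900 nM
Compound 3 `Nc1ccccc1NC(=O)C1(S(=O)(=O)c2ccc(NC3CCCCC3)cc2)CCC2(CCNCC2)C1` gives <= 400 nM

Compound 3 has <= 400 nM as a limit of the assay and not as a number. Compound 3 thus stands at the limit of <= 400 nM in this assay, at which 1 of the 3 values shown sits, on the numbers shown.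

Compound 4 `O=C(Oc1ccccc1)C1(S(=O)(=O)c2ccc(NC3CCCCC3)cc2)CCC2(CCNCC2)C1` differs from compound 3 at one place (phenoxy in place of (2-aminophenyl)amino on a carbonyl carbon). In words, phenoxy stands in place of (2-aminophenyl)amino on a carbonyl carbon.

The step of no change at the digits printed from compound 1 to compound 2 (within the scatter) is the same exchange in reverse, on a background carrying 4-(trifluoromethoxy)phenoxy where compound 3 carries cyclohexylamino. The step of an at least 2.2-fold lower number from compound 2 to compound 3 (0.35 log units; beyond the scatter) belongs to the other place (cyclohexylamino in place of 4-(trifluoromethoxy)phenoxy on an aromatic carbon) and leaves the carbonyl carbon and its phenoxy or (2-aminophenyl)amino group out of the comparison.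

Among the compounds with values here, only that single pair, compound 1 and compound 2, speaks directly to this exchange. No step beyond the scatter is therefore expected in this assay for this change. The estimated step is a step that the limit leaves unreadable from compound 3 to compound 4 as an expectation only. The estimated value for compound 4 is 350 nM (expected range 130 nM to 900 nM).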

Compound 4, half-maximal effective concentration: > 15000 nM
Compound 4 was reported as a limit (the forecaster's own chance of this, stated with the estimate: 35%); middle value at least 42-fold (1.63 log units) away from the limit.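

In this assay, the exchange on the carbonyl carbon proves to depend on the group at the other place: with cyclohexylamino on the aromatic carbon, phenoxy in place of (2-aminophenyl)amino gives an at least 37-fold higher number from compound 3 to compound 4 (1.57 log units; beyond the scatter), a large step that the 4-(trifluoromethoxy)phenoxy background did not show: the same change on two cores in this assay, no change at the digits printed (within the scatter) from compound 1 to compound 2 and an at least 37-fold lower number (1.57 log units; beyond the scatter) from compound 4 to compound 3, at least 37-fold (1.57 log units) apart, beyond the scatter of two such steps

Read from the other place, cyclohexylamino in place of 4-(trifluoromethoxy)phenoxy does not act the same way on both backgrounds, giving an at least 2.2-fold lower number from compound 2 to compound 3 (0.35 log units; beyond the scatter) with (2-aminophenyl)amino on the carbonyl carbon but an at least 16-fold higher number from compound 1 to compound 4 (1.22 log units; beyond the scatter) with phenoxy there: the same change on two cores in this assay, an at least 2.2-fold lower number (0.35 log units; beyond the scatter) from compound 2 to compound 3 and an at least 16-fold higher number (1.22 log units; beyond the scatter) from compound 1 to compound 4, at least 37-fold (1.57 log units) apart, beyond the scatter of two such steps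

Compound 4 gives > 15000 nM, which is a limit of the assay and not a number.

Going by these compounds, compound 3 gives <= 400 nM, which is also a limit of the assay, and the true size of the steps that involve these two compounds stays open. On these data alone, it also stays open how a plain phenylamino group, without the amine of (2-aminophenyl)amino, or a carboxylic acid on the carbonyl carbon would read on the cyclohexylamino background, and so which part of (2-aminophenyl)amino goes with the lower number.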